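The source may report more compounds than this note shows. Statements on the series, on what has been measured and on what is new or still open speak of the compounds shown alone.

Compound 1 `O=C(Nc1cc(F)cc(F)c1)c1cc(=O)[nH]c2cc(Cl)ccc12` — 11000 nM
Compound 2 `CC(C)(C)c1ccc(-c2ccc3c(C(=O)Nc4cccc(F)c4)cc(=O)[nH]c3c2)cc1` — > 20000 nM

In a functional assay on KYSE-410 cells (Homo sapiens) for antiproliferative activity, read by MTT assay, with a stated time of 72 h (on this read-out lower numbers stand for stronger inhibition and higher numbers for weaker inhibition), compound 1 gives 11000 nM. For compound 2 the read-out is only a limit, > 20000 nM, so compound 2 stands at the limit of > 20000 nM in this assay, at which 1 of the 2 values shown sits, and not at a number. Compound 3 `O=C(Nc1cccc(F)c1)c1cc(=O)[nH]c2cc(C3=CCOCC3)ccc12` differs from compound 2 by a group of 6 heavy atoms (5 carbon, 1 oxygen; one six-membered non-aromatic ring with 1 hetero atom) in place of a group of 10 heavy atoms (10 carbon; one six-membered aromatic ring of carbon only), on an aromatic carbon. Among the measured compounds shown here, no step between measured compounds is available, so the weight of this change is unknown. Compound 3 is expected to show a step of an at least 1.3-fold lower number from compound 2 to compound 3 (0.12 log units; that floor lies within the scatter) toward stronger inhibition, though a result at the limit remains possible. Compound 3 is estimated at 15000 nM, between 5000 nM and 40000 nM.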

Compound 3, half-maximal inhibitory concentration: 12100 nM
Compound 3: middle estimate off by 1.2-fold (0.09 log units), on the high side; low and high end bracket the measured number.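

In this assay, a six-membered non-aromatic ring with 1 hetero atom in place of 4-(tert-butyl)phenyl on this aromatic carbon gives an at least 1.6-fold lower number from compound 2 to compound 3 (0.21 log units; that floor lies within the scatter). Compound 2 is held at a limit and not at a number: the limit of > 20000 nM in this assay, at which 1 of the 3 values shown sits. The change thus brings a measured number at this position, 12100 nM for compound 3, but the true size of the step cannot be read.

As far as these compounds go, what an amine or a carboxylic acid would do on this aromatic carbon stays open. So does whether the 4-(tert-butyl)phenyl group or the ring that replaces it matters more.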